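The source may hold more compounds than are shown below. What is called first, only, known or untested is meant among the compounds shown, and "the series" means these compounds.

Compound 1 `Cc1cn([C@@H]2O[C@H](CO[Si](C)(C)C(C)(C)C)[C@@]3(OS(=O)(=O)C=C3NC(=O)NCc3ccccc3)[C@H]2O[Si](C)(C)C(C)(C)C)c(=O)n(C)c1=O`: in an ADME assay on HEL cells (Homo sapiens) for cytotoxicity, with a stated time of 3 days (a higher number here means that more compound is tolerated, a lower number that less compound is tolerated), compound 1 gives 4000 nM.
Compound 2 `CCNC(=O)NC1=CS(=O)(=O)O[C@@]12[C@@H](CO[Si](C)(C)C(C)(C)C)O[C@@H](n1cc(C)c(=O)n(C)c1=O)[C@@H]2O[Si](C)(C)C(C)(C)C`: in this assay compound 2 gives >= 3200 nM, which is a limit of the assay.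

Within the data shown here, compound 2 therefore sits at the limit of >= 3200 nM in this assay, at which 1 of the 2 values shown sits, and the only measured step, a step that the limit leaves unreadable from compound 1 to compound 2, cannot be read. Compound 3 `CCOC(=O)CNC(=O)NC1=CS(=O)(=O)O[C@@]12[C@@H](CO[Si](C)(C)C(C)(C)C)O[C@@H](n1cc(C)c(=O)n(C)c1=O)[C@@H]2O[Si](C)(C)C(C)(C)C` differs from compound 2 by ethoxycarbonyl in place of methyl on a saturated chain carbon bound to an amide-type nitrogen. With no readable step to lean on, compound 3 is expected to stay close to compound 2, a step that the limit leaves unreadable from compound 2 to compound 3 in this assay. The estimate for compound 3 is 4000 nM, with a range from 1600 nM to 10000 nM.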

Compound 3, minimum cytotoxic concentration: 16000 nM
The estimate for compound 3 lay 4.0-fold (0.60 log units) below the measured number, outside the stated range (above it).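

Among these compounds, at the saturated chain carbon bound to an amide-type nitrogen, ethoxycarbonyl in place of phenyl gives the first readable step at this position in this assay, a 4.0-fold higher number from compound 1 to compound 3 (0.60 log units; beyond the scatter). The value of compound 2 is a limit of the assay, so neither step involving compound 2 can be read: the limit of >= 3200 nM in this assay, at which 1 of the 3 values shown sits. On these data alone, the position therefore does affect how much compound is tolerated, but where methyl stands relative to ethoxycarbonyl or phenyl stays unknown. As far as these compounds go, whether a carboxylic acid or an amine at the end of the chain would keep this higher number remains open.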